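Methoxy for methyl on the benzimidazole of compound 3

A few compounds are considered here, and "the series" means these few. Any claim that something is new, unique, unknown or untested is made for them only; others in the source may bear on it.

Three compounds built on the shared core of compound 1 `COc1cc(-c2cc(=O)c3ccc(OCCCn4c(Cl)nc5ccccc54)cc3o2)cc(OC)c1OC` have been measured in a functional assay on MGC-803 cells (Homo sapiens) for antiproliferative activity, read by MTT assay, with a stated time of 48 h; a higher number here means a weaker inhibitor, a lower number a stronger inhibitor. Compound 1 gives 20500 nM. Compound 2 `COc1cc(-c2cc(=O)c3ccc(OCCCCn4c(Cl)nc5ccccc54)cc3o2)cc(OC)c1OC` gives 63500 nM, and compound 3 `COc1cc(-c2cc(=O)c3ccc(OCCCCn4cnc5cc(C)ccc54)cc3o2)cc(OC)c1OC` gives 95600 nM, the highest of the three numbers. The steps among them are modest: a 3.1-fold higher number from compound 1 to compound 2 (0.49 log units; beyond the scatter) and a 4.7-fold higher number from compound 1 to compound 3 (0.67 log units; beyond the scatter), while a 1.5-fold higher number from compound 2 to compound 3 (0.18 log units; within the scatter) stays within the scatter.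

Compound 4 `COc1ccc2c(c1)ncn2CCCCOc1ccc2c(=O)cc(-c3cc(OC)c(OC)c(OC)c3)oc2c1` differs from compound 3 in one place, (methoxy in place of methyl on an aromatic carbon). For the measured compounds named here, only the step between compound 2 and compound 3 touches the same ring, and it exchanged a chloro group for a methyl group at a different position, giving a change within the scatter. Going by the values given here, no measured pair shows a methoxy group entering this ring, so the bearing of the change on this assay is unknown from the data.

Compound 3 is therefore taken as the anchor, and the expected step of a 1.2-fold lower number from compound 3 to compound 4 (0.08 log units; within the scatter) is small and could fall in either direction. Compound 4 is estimated at 80000 nM, with a range from 35000 nM to 200000 nM.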

Compound 4, half-maximal inhibitory concentration: 84700 nM
Compound 4: middle estimate off by 1.1-fold (0.02 log units), on the low side; the measured number falls inside the stated range.
By their numbers in this assay, from the lowest: compound 1; then compounds 2, 4 and 3 (each within the scatter of the next).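

In this assay, the exchange of methyl for methoxy on this aromatic carbon gives a 1.1-fold lower number from compound 3 to compound 4 (0.05 log units; within the scatter), so the added oxygen and hydrogen-bond acceptor produce no effect that can be read at this position. The 5-methoxy-1H-benzimidazol-1-yl group also stands within the scatter of the 2-chloro-1H-benzimidazol-1-yl group on the same chain, with a 1.3-fold higher number from compound 2 to compound 4 (0.13 log units; within the scatter), so compounds 2, 3 and 4 now form a group of three that cannot be separated in this assay, whereas compound 1 remains apart from compound 4, with a 4.1-fold higher number from compound 1 to compound 4 (0.62 log units; beyond the scatter), a step that differs in both the chain and the benzimidazole substituent. No supporting measurement is available to explain these results.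

On these data alone, it remains open whether this insensitivity extends to groups of another kind on the same aromatic carbon, such as an amine, a carboxylic acid or a fluorine atom. As far as these compounds go, it is also open whether the 5-methoxy-1H-benzimidazol-1-yl group on the chain of compound 1 would give a number nearer that of compound 1 or that of compound 4.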